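Pyrazine hydrazones: cytotoxicity on mouse macrophage-like cells

The source may hold more compounds than are shown below. What is called first, only, known or untested is meant among the compounds shown, and "the series" means these compounds.

Two pyrazine carbohydrazide hydrazones have been measured in an ADME assay on J774 cells (Mus musculus) for cytotoxicity, read by MTT assay, with a stated time of 48 h, tested at 50 ug/mL; on this read-out lower numbers stand for a stronger effect and higher numbers for a weaker effect at the one concentration tested. Compound 1, `O=C(N/N=C/c1ccccc1Cl)c1cnccn1`, carries a chloro group on its benzylidene ring and in this assay compound 1 gives 70%. Compound 2, `O=C(N/N=C/c1ccc(Br)cc1)c1cnccn1`, carries a bromo group instead; in this assay compound 2 gives 100%. Of the two numbers shown, compound 2 stands higher, and the gap to compound 1 lies beyond the usual scatter, so compound 2 shows the weaker effect at the one concentration tested.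

The next compound in the series is compound 3, `N#Cc1ccc(/C=N/NC(=O)c2cnccn2)cc1`. Its difference from compound 2 is cyano in place of bromo on an aromatic carbon. Within the data shown here, no step between measured compounds shows what such a change does in this assay, so the expectation rests on compound 2 alone. Compound 3 is expected to stay close to compound 2, with a step of a number 10 percentage points lower from compound 2 to compound 3 (within the scatter) that may reach slightly below the scatter but is as likely to stay within it. The estimate for compound 3 in this assay is 90%, between 65% and 110%.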

Compound 3, a percentage reported as activity, at one concentration (the size of the read-out at that concentration, not a potency): 100%
For compound 3 the middle estimate is 10 percentage points below the measured one; low and high end bracket the measured number.
By their numbers in this assay, from the lowest: compound 1; then compounds 2 and 3 (each within the scatter of the next).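

In this assay, cyano in place of bromo on an aromatic carbon, para to a large group, brings no change at the digits printed from compound 2 to compound 3 (within the scatter). Among these compounds, this is the first step that changes a single place, and it shows that at this position a bromo group, with one heavy atom and no hydrogen-bond acceptor, can give way to a cyano group, with two heavy atoms, a triple bond and one hydrogen-bond acceptor, without a change in the read-out beyond the scatter. Nothing at hand explains why this exchange leaves the read-out where it is.

The compounds shown leave open whether this position would accept very different groups, such as an amine, a carboxylic acid or a longer chain, with the same result. They also leave open what lies behind the value of 70% for compound 1, which differs from compound 2 and compound 3 in more than one place, so that its chloro group and the place of that group cannot be told apart.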